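This account rests on a few compounds, and the source may have more. Where it says the series, first, only, none or still open, it means among the compounds named here.

compound 1 `CC(C)CCn1c(Cn2c(=O)n(C(C)C)c3ccccc32)nc2cc(CN(C)C)ccc21`: 5650 nM
compound 2 `C=Cc1ccc2c(c1)nc(Cn1c(=O)n(C(C)C)c3ccccc31)n2CCC(C)C`: 6520 nM

Both values come from an ADME assay on HEp-2 cells (Homo sapiens) for cytotoxicity; a higher number here means that more compound is tolerated, a lower number that less compound is tolerated. Among the measured compounds shown here, the only measured step is a 1.2-fold higher number from compound 1 to compound 2 (0.06 log units; within the scatter), with vinyl in place of (dimethylamino)methyl on an aromatic carbon. On these numbers, compound 2 cannot be told apart from compound 1.

Compound 3 `CC(C)CCn1c(Cn2c(=O)n(C(C)C)c3ccccc32)nc2cc(-c3ncon3)ccc21` has not yet been measured. It carries 1,2,4-oxadiazol-3-yl in place of vinyl on the same aromatic carbon: 1,2,4-oxadiazol-3-yl in place of vinyl on an aromatic carbon. The step between compound 1 and compound 2 is the only one that bears on this change, and it stayed within the scatter. For the measured compounds named here, with a 1.2-fold higher number from compound 1 to compound 2 (0.06 log units; within the scatter) as the sole guide, no step beyond the scatter is expected in this assay, and so no direction is favoured. The evidence is thin, however, as it is a single pair and neither measured compound has a ring at that carbon. The range is therefore kept wide. The estimated change is a 1.1-fold lower number from compound 2 to compound 3 (0.04 log units; within the scatter). For compound 3 the expected value is 6000 nM, with an estimated range of 2500 nM to 14000 nM.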

Compound 3, half-maximal cytotoxic concentration: 223000 nM
Compound 3: the middle estimate sits 37-fold (1.57 log units) below what was measured; the measured number lies above the stated range.
By their numbers in this assay, from the lowest: compounds 1 and 2 (each within the scatter of the next); then compound 3.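

In this assay the aromatic carbon carrying these groups proves far from indifferent to what is placed there, with a 34-fold higher number from compound 2 to compound 3 (1.53 log units; beyond the scatter) when 1,2,4-oxadiazol-3-yl replaces vinyl and a 39-fold higher number from compound 1 to compound 3 (1.60 log units; beyond the scatter) when it replaces (dimethylamino)methyl. Among the compounds shown here, the two groups compared earlier had stayed within the scatter of each other, so those compounds gave no sign that a change at this carbon could shift the number so far, and compound 3, the only one of the three with a ring there, now stands well apart from both. Nothing available here bears on what lies behind this step.

With a single ring group at this carbon, the compounds shown cannot separate the effect of having a five-membered aromatic ring there from the effect of this particular arrangement of nitrogen and oxygen atoms; a phenyl ring or the isomeric 1,3,4-oxadiazol-2-yl on the same carbon would speak to that. On these data alone, it also remains open whether a simple carboxylic acid or a primary amide there would stay with compounds 1 and 2 or move toward compound 3.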